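Hydroxy for fluoro on the side chain of compound 3

The compounds below may be only part of what the source reports. "The series", "measured", "known", "first", "only" and "open" are said of these compounds alone.

The series keeps the core of compound 1 `Cc1cn([C@@H]2O[C@H](CO)[C@@H](CO)[C@H]2O)c(=O)[nH]c1=O` and varies the group on a saturated chain carbon bound to a saturated ring carbon. In a functional assay on L1210 cells (Mus musculus) for antiproliferative activity, with a stated time of 72 h (a lower number here means that less compound is needed, a higher number that more compound is needed for the effect), compound 1 reaches only a limit, > 100 uM. Compound 2 `Cc1cn([C@@H]2O[C@H](CO)[C@@H](CN=[N+]=[N-])[C@@H]2O)c(=O)[nH]c1=O` carries azido at that place and gives 10 uM in this assay. Compound 3 `Cc1cn([C@@H]2O[C@H](CO)[C@@H](CF)[C@@H]2O)c(=O)[nH]c1=O` carries fluoro at that place; in this assay compound 3 also reaches only a limit, > 100 uM. Among the measured compounds shown here, the single measured step, an at least 10-fold higher number from compound 2 to compound 3 (1.00 log units; beyond the scatter), ends at that limit, and the limit of > 100 uM in this assay, at which 2 of the 3 values shown sit, marks where compound 3 stands: at the edge of what this assay reports, with no number of its own.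

Compound 4 `Cc1cn([C@@H]2O[C@H](CO)[C@@H](CO)[C@@H]2O)c(=O)[nH]c1=O` differs from compound 3 by hydroxy in place of fluoro on a saturated chain carbon bound to a saturated ring carbon. For the measured compounds named here, no measured step covers hydroxy entering in place of fluoro, so the step from compound 2 to compound 3 bears on it only in that both fluoromethyl and hydroxymethyl sit at the limit in this assay. For compound 4 no step beyond the scatter is expected, and the expected shift a step that the limit leaves unreadable from compound 3 to compound 4 is read as a return of the same limit rather than a real change. Compound 4 is therefore estimated at 200 uM, within 50 uM to 1000 uM, most likely again a limit.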

Compound 4, concentration for half-maximal effect: > 100 uM
Compound 4 was reported as a limit; the forecaster's own chance of this, stated with the estimate: 80%; the middle value does not contradict the limit.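

In this assay compound 4 gives > 100 uM, which is a limit and not a number. Hydroxy in place of azido gives an at least 10-fold higher number from compound 2 to compound 4 (1.00 log units; beyond the scatter), and with an at least 10-fold higher number from compound 2 to compound 3 (1.00 log units; beyond the scatter) this leaves azido as the only group at this place with a measured value among those shown. The steps from compound 3 to compound 4 and from compound 1 to compound 4 cannot be read, so hydroxy and fluoro cannot be ranked against each other in this assay: the limit of > 100 uM in this assay, at which 3 of the 4 values shown sit.

Going by these compounds, it is open whether an amine or a longer chain carrying azido on the same saturated chain carbon would keep a measurable value in this assay, where compound 2 gives 10 uM. What the drawn configuration contributes in this assay also stays open, since both compounds of that pair end at the limit: the fact that compounds 1 and 4 differ only in the configuration as drawn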